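Fluoro added beside the methylsulfonyl group on a pyrimidinyl spirocycle

The source may report more compounds than this note shows. Statements on the series, on what has been measured and on what is new or still open speak of the compounds shown alone.

Measured compounds:
compound 1, `CC(C)(C)OC(=O)N1CCC2(CC1)CC(CCCOc1ccc(S(C)(=O)=O)cc1)C2`, 14 nM
compound 2, `CC(C)(C)OC(=O)N1CCC2(CC1)CC(CCCOc1ccc(S(C)(=O)=O)cc1F)C2`, 25 nM
compound 3, `CCc1cnc(N2CCC3(CC2)CC(CCCOc2ccc(S(C)(=O)=O)cc2)C3)nc1`, 31 nM

All three were tested in a functional assay on cells for agonist activity at Glucose-dependent insulinotropic receptor (Homo sapiens), read by HTRF and cAMP accumulation, with a stated time of 30 min; on this read-out lower numbers stand for an effect already at smaller amounts and higher numbers for an effect only at larger amounts of compound. Compound 3 differs from compound 1 by 5-ethylpyrimidin-2-yl in place of tert-butoxycarbonyl on an amine nitrogen in a ring; that change cost a 2.2-fold higher number from compound 1 to compound 3 (0.35 log units; beyond the scatter). Compound 2 differs from compound 1 by fluoro in place of hydrogen on an aromatic carbon, and the step was a 1.8-fold higher number from compound 1 to compound 2 (0.25 log units; within the scatter).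

Compound 4, `CCc1cnc(N2CCC3(CC2)CC(CCCOc2ccc(S(C)(=O)=O)c(F)c2)C3)nc1`, has not yet been measured. It differs from compound 3 by fluoro in place of hydrogen on an aromatic carbon. Among the measured compounds shown here, this is the same kind of change as the one from compound 1 to compound 2, but not the same: there the fluoro sits ortho to a large group and meta to a methylsulfonyl group, whereas here it sits ortho to the methylsulfonyl group and meta to a large group. Because compound 2 gave 25 nM after the fluoro entered, only a small step is expected here as well, though the different place around the fluoro adds uncertainty. From compound 3 to compound 4 in this assay, a step of a 1.5-fold higher number from compound 3 to compound 4 (0.16 log units; within the scatter) is expected. Compound 4 is therefore estimated at 45 nM, with a likely range from 20 nM to 110 nM.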

Compound 4, half-maximal effective concentration: 123 nM
Compound 4: the middle estimate sits 2.7-fold (0.44 log units) below what was measured, and the stated range ends below it.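

In this assay, the same replacement of hydrogen by fluoro on an aromatic carbon gave a 4.0-fold higher number from compound 3 to compound 4 (0.60 log units; beyond the scatter), and the two steps seen on the two cores do not separate: the same change on two cores in this assay, a 1.8-fold higher number (0.25 log units; within the scatter) from compound 1 to compound 2 and a 4.0-fold higher number (0.60 log units; beyond the scatter) from compound 3 to compound 4, 2.2-fold (0.35 log units) apart, within the scatter of two such steps

The data therefore give no ground for saying that the core alters the effect of the fluoro, but they do not show that the effect carries over unchanged either. The comparison is also not a clean one: in compound 4 the fluoro sits ortho to a methylsulfonyl group, whereas in compound 2 it stands elsewhere on the ring, and a single pair of steps cannot tell core and place apart.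

The compounds shown leave open how each core behaves with the fluoro at the place it holds on the other. They also leave open whether a chloro or methoxy group on the same carbon, or an amide in place of the methylsulfonyl group, would follow the same course.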